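The source may report more compounds than this note shows. Statements on the series, on what has been measured and on what is new or still open speak of the compounds shown alone.

Measured so far in an assay on isolated protein (Oryctolagus cuniculus) for inhibition of glycogen phosphorylase, brain form (Homo sapiens); on this read-out lower numbers stand for stronger inhibition and higher numbers for weaker inhibition: compound 1 `NCC1OC(CO)C(O)C(O)C1O` gives 16800000 nM; 34500000 nM (2 entries); compound 2 `[N-]=[N+]=NC[C@H]1O[C@H](CO)[C@@H](O)[C@H](O)[C@H]1O` gives 22400000 nM; compound 3 `O=C(Nc1ccccc1)C1OC(CO)C(O)C(O)C1O` gives 5400000 nM.

Compound 1 has no single number, only the two repeat entries of the several entries of compound 1 in this assay, 16800000 nM; 34500000 nM (2 entries), so the comparison rests on compound 2 and compound 3. Of these two, compound 2 stands with the higher number; compound 3 sits lower, and that gap lies beyond the usual scatter. Going by the values given here, no step between two measured compounds that differ in one place is available, so the effect of any single change is not yet known from measurement.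

Compound 4 `CNNC(=O)[C@H]1O[C@H](CO)[C@@H](O)[C@H](O)[C@H]1O` is the next member and is still to be measured in this assay. It differs from compound 2 by (methylamino)carbamoyl in place of azidomethyl on a saturated ring carbon. Compound 4 thus carries a carbonyl-bearing group at the same position where compound 3 also carries one, and compound 3 gave the lower number of the two measured.

On that basis the step from compound 2 to compound 4 is expected to go downward, a 5.6-fold lower number from compound 2 to compound 4 (0.75 log units; beyond the scatter), most likely beyond the scatter but not by a large margin. For compound 4 the expected value in this assay is 4000000 nM, with a plausible range from 1000000 nM to 15000000 nM.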

Compound 4, inhibition constant: 1800000 nM
Compound 4: middle estimate off by 2.2-fold (0.35 log units), on the high side; low and high end bracket the measured number.
By their numbers in this assay, from the lowest: compound 4; then compound 3; then compound 2.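

In this assay, going by these compounds alone, the position on a saturated ring carbon next to the ring oxygen proves sensitive to what it carries: replacing azidomethyl with (methylamino)carbamoyl gives a 12-fold lower number from compound 2 to compound 4 (1.09 log units; beyond the scatter), the first single-place change with a measured size. The exchange alters several things at once, since the entering group brings a carbonyl and two hydrogen-bond donors while the leaving group has no donor, so the step belongs to the whole group and not to any one of its parts. Within the data shown here, the only supporting measurement available, the repeat entries of compound 1, does not bear on the reason for this step.

Still open, on these data alone, is whether the carbonyl or the methylamino end of the entering group accounts for the step, a question that a primary carboxamide or a carboxylic acid at the same position would help to separate. Also open, as far as these compounds go, is how the number responds to a longer chain, such as ethyl or propyl in place of the terminal methyl, on the shared core of compound 4.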